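Series notes: biaryl benzylureas on the piperidine core

The compounds below may be only part of what the source reports. "The series", "measured", "known", "first", "only" and "open" are said of these compounds alone.

Measured so far:
- compound 1, `Cc1ccc(CN2CCC(NC(=O)NCc3ccc(-c4cccc(C#N)c4)cc3)CC2)cc1`: 98%
- compound 2, `Cc1ccc(CN2CCC(NC(=O)N(CC(=O)C(C)(C)O)Cc3ccc(-c4ccc(F)cc4)cc3)CC2)cc1`: 79%
- compound 3, `COc1ccccc1-c1ccc(CN(CC(=O)C(C)(C)O)C(=O)NC2CCN(Cc3ccc(C)cc3)CC2)cc1`: 68.3%

In an in vitro functional assay on HEK293 cells for antagonist activity at melanin-concentrating hormone receptor 1 (Homo sapiens) (on this read-out higher numbers stand for larger maximal responses and lower numbers for smaller maximal responses), compound 3 stands lowest of the three numbers. Among the compounds with values here, its nearest neighbour is compound 2, and the measured step of a number 10.7 percentage points lower from compound 2 to compound 3 (beyond the scatter) is the only one between compounds that differ in a single place. Compound 1 gives the highest number, but it differs from compound 3 in more than one place, so only the two values can be set side by side.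

The next compound is compound 4, `Cc1ccc(CN2CCC(NC(=O)N(CC(=O)C(C)(C)O)Cc3ccc(-c4cccc(C#N)c4)cc3)CC2)cc1`. It differs from compound 3 as follows: 3-cyanophenyl in place of 2-methoxyphenyl on an aromatic carbon. Within the data shown here, the aryl group that enters is the one found in compound 1; no measured step isolates this exchange on the scaffold carrying the hydroxy-keto chain. Among the measured compounds shown here, the one step that does bear on aryl exchange, a number 10.7 percentage points lower from compound 2 to compound 3 (beyond the scatter), was modest in size and downward on going to 2-methoxyphenyl. Reversing that loss seems the most that can be expected; a gain beyond compound 2 is not supported. Compound 4 is therefore expected to give about 78% in this assay, in a range from 62% to 92%, an estimated step of a number 9.7 percentage points higher from compound 3 to compound 4 (within the scatter).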

Compound 4, largest response reached (reported as Imax), in percent of the reference or control that the assay uses: 84.5%
For compound 4 the middle estimate is 6.5 percentage points below the measured one; the range from low to high includes it.
By their numbers in this assay, from the lowest: compound 3; then compounds 2 and 4 (each within the scatter of the next); then compound 1.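

In this assay, 3-cyanophenyl in place of 2-methoxyphenyl gives a number 16.2 percentage points higher from compound 3 to compound 4 (beyond the scatter) and, in place of 4-fluorophenyl, gives a number 5.5 percentage points higher from compound 2 to compound 4 (within the scatter) on the scaffold carrying the hydroxy-keto chain, so of these three aryl groups only 2-methoxyphenyl stands apart at this position. Within the data shown here, with 3-cyanophenyl held fixed, ((1-hydroxy-1-methylethyl)carbonyl)methyl in place of hydrogen on the amide-type nitrogen gives a number 13.5 percentage points lower from compound 1 to compound 4 (beyond the scatter) as the first isolated reading of that chain. No measurement on hand accounts for either change.

Going by these compounds, whether the lower number of compound 3 follows the methoxy group or its place on the ring remains open, and 3-methoxyphenyl or 2-cyanophenyl would separate the two. On these data alone, whether the cost of the chain carries over to other aryl groups, or to a shorter chain such as 2-hydroxyethyl, also remains open.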